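Furan and thiophene nucleosides: cytotoxicity notes on MRC5 cells

The source may report more compounds than this note shows. Statements on the series, on what has been measured and on what is new or still open speak of the compounds shown alone.

Compound 1 `O=c1[nH]cnc2c1c(-c1ccoc1)cn2[C@@H]1O[C@H](CO)[C@@H](O)[C@H]1O` and compound 3 `O=c1[nH]cnc2c1c(-c1cccs1)cn2[C@@H]1O[C@H](CO)[C@@H](O)[C@H]1O` share a core; how compound 2 `COc1ncnc2c1c(-c1ccoc1)cn2[C@@H]1O[C@H](CO)[C@@H](O)[C@H]1O` differs from compound 1 is not broken down here. Compound 4 `COc1ncnc2c1c(-c1cccs1)cn2[C@@H]1O[C@H](CO)[C@@H](O)[C@H]1O` is not yet measured. In an ADME assay on MRC5 cells (Homo sapiens), read by MTT assay, with a stated time of 72 h (on this read-out higher numbers stand for weaker inhibition and lower numbers for stronger inhibition), compound 1 gives > 100000 nM, which is a limit of the assay and not a number. In this assay compound 3 gives > 100000 nM, also a limit. The step that the two limits leave unreadable from compound 1 to compound 3 therefore cannot be read, and the change thiophen-2-yl in place of furan-3-yl on an aromatic carbon gives no measurable size, because both values sit at the limit of > 100000 nM in this assay, at which 2 of the 3 values shown sit. Within the data shown here, compound 2 is the only compound with a number: in this assay compound 2 gives 29400 nM.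

The change from compound 2 to compound 4 is the same, (thiophen-2-yl in place of furan-3-yl on an aromatic carbon). With the step from compound 1 to compound 3 unreadable, the expected step of a 1.2-fold higher number from compound 2 to compound 4 (0.08 log units; within the scatter) rests on nothing measurable and is set near zero. Compound 4 is estimated at 35000 nM, with a range of 12000 nM to 100000 nM, and a real chance that only a limit is reported.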

Compound 4, half-maximal inhibitory concentration: 43200 nM
For compound 4 the middle estimate is 1.2-fold (0.09 log units) below the measured one; low and high end bracket the measured number.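

On the core of compound 2, thiophen-2-yl in place of furan-3-yl gives a 1.5-fold higher number from compound 2 to compound 4 (0.17 log units; within the scatter) in this assay, so on this core the swap of one five-membered aromatic ring for the other makes no difference that can be told from scatter. The step from compound 1 to compound 3 cannot be read, because both compounds sit at a limit of the assay and not at a number: the limit of > 100000 nM in this assay, at which 2 of the 4 values shown sit. Carrying the change from one core to the other is therefore untested: only one readable step exists, it holds for this pair alone, and there is no second size to set against it.

The compounds shown leave open what an amine, a carboxylic acid or a longer chain would do in this assay on the same aromatic carbon of the five-membered aromatic ring with 1 nitrogen. They also leave open whether furan-2-yl or thiophen-3-yl would read the same as the two rings shown there.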